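Guanidine-to-Dimethylamino Swap in a Benzothiazole Calcium Channel Series

The source may report more compounds than this note shows. Statements on the series, on what has been measured and on what is new or still open speak of the compounds shown alone.

Measured compounds:
Compound 1, `CN(C)CCCOc1ccc(CN(C)c2nc3ccc(Oc4ccc(C(F)(F)F)cc4)cc3s2)cc1`, 46000 nM
Compound 2, `CN(Cc1ccc(OCCCNC(=N)N)cc1)c1nc2ccc(Oc3ccc(C(F)(F)F)cc3)cc2s1`, 185000 nM
Compound 3, `N=C(N)NCCCOc1ccc(CNc2nc3ccc(Oc4ccc(F)cc4)cc3s2)cc1`, 244000 nM

Three compounds have been characterised in an assay on SH-SY5Y cells for inhibition of Voltage-dependent N-type calcium channel subunit alpha-1B (Homo sapiens), read by FLIPR and calcium flux, with stated times of 600 s and 300 s, in the presence of a further agent that is not named here; on this read-out lower numbers stand for stronger inhibition and higher numbers for weaker inhibition. Compound 1 gives 46000 nM, compound 2 gives 185000 nM and compound 3 gives 244000 nM. Compounds 2 and 1 differ in one place: a group of 3 heavy atoms (2 carbon, 1 nitrogen; no ring) in place of a group of 4 heavy atoms (1 carbon, 3 nitrogen; no ring), on a saturated chain carbon, three bonds along the chain from an oxygen on an aromatic ring. That change produced a 4.0-fold lower number from compound 2 to compound 1 (0.60 log units; beyond the scatter). Compound 3 sits highest of the three numbers; its gap to compound 2 lies within the scatter, while its gap to compound 1 lies beyond it. The difference between the cores of compound 3 and compound 2 is not broken down here.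

Compound 4, `CN(C)CCCOc1ccc(CNc2nc3ccc(Oc4ccc(F)cc4)cc3s2)cc1`, has not yet been measured in this assay. It is related to compound 3 by a group of 3 heavy atoms (2 carbon, 1 nitrogen; no ring) in place of a group of 4 heavy atoms (1 carbon, 3 nitrogen; no ring), on a saturated chain carbon, three bonds along the chain from an oxygen on an aromatic ring, the same change that links compound 2 to compound 1, occurring twice among these compounds. Because the earlier step was a 4.0-fold lower number from compound 2 to compound 1 (0.60 log units; beyond the scatter), compound 4 is expected to show a step of about a 4.0-fold lower number from compound 3 to compound 4 (0.60 log units; beyond the scatter) from compound 3. This expectation rests on a single prior instance of the change, made on a different core, so it carries considerable uncertainty. The estimate for compound 4 is 61000 nM, with a plausible range from 25000 nM to 150000 nM.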

Compound 4, half-maximal inhibitory concentration: 40000 nM
Beside the measured number, compound 4's estimate is 1.5-fold (0.18 log units) above it, and the stated range covers the measured number.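

In this assay, replacing the group of 4 heavy atoms (1 carbon, 3 nitrogen) with dimethylamino, on a saturated chain carbon three bonds along the chain from an oxygen on an aromatic ring, gives a 6.1-fold lower number from compound 3 to compound 4 (0.79 log units; beyond the scatter). This second instance does not show that the change would behave in the same way on any core beyond these two, and the two cores differ from each other in more than one place, so the pairs cannot say whether any single part of the core influences the size of the step. Within these limits, the change carried over from one core to the other at a comparable size, with both steps pointing to lower numbers: the same change on two cores in this assay, a 4.0-fold lower number (0.60 log units; beyond the scatter) from compound 2 to compound 1 and a 6.1-fold lower number (0.79 log units; beyond the scatter) from compound 3 to compound 4, 1.5-fold (0.18 log units) apart, within the scatter of two such steps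

The compounds shown leave open whether the lower number is particular to dimethylamino or would also appear with a primary amine, a morpholine or a carboxylic acid at the same place on the chain. They also leave open how a longer chain or a shorter chain between the oxygen and dimethylamino would affect the number on either core.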